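This account rests on a few compounds, and the source may have more. Where it says the series, first, only, none or still open, it means among the compounds named here.

Among the measured compounds shown here, in an ADME assay on microsomes from liver (Mus musculus) for metabolic stability, read by LC-MS, with a stated time of 30 min, tested at 1 uM (a lower number here means that less of the compound is left, a higher number that more of the compound is left), three related amides have numbers so far. Compound 1 `O=C(NCc1ccc(S(=O)(=O)c2ccccc2)cc1)c1cc2ccncc2s1` gives 21%, compound 3 `O=C(NCc1ccc(S(=O)(=O)c2ccccc2)cc1)c1cc(-c2cccnc2)no1` gives 66%, and compound 2 `O=C(NCc1ccc(S(=O)(=O)N2CCCCC2)cc1)c1cc2cnccc2o1` gives 4.6%. That makes compound 2 the lowest of the three, and both of the other numbers lie above it by more than the usual scatter of repeated measurements.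

The next compound to be measured, compound 4 `O=C(NCc1ccc(S(=O)(=O)N2CCCCC2)cc1)c1ccc2nc[nH]c2c1`, differs from compound 2 in a single place, the group on the carbonyl carbon: a group of 9 heavy atoms (7 carbon, 2 nitrogen; one five-membered aromatic ring with 2 hetero atoms, one six-membered aromatic ring of carbon only) in place of a group of 9 heavy atoms (7 carbon, 1 nitrogen, 1 oxygen; one five-membered aromatic ring with 1 hetero atom, one six-membered aromatic ring with 1 hetero atom), on a carbonyl carbon. The group that enters is 1H-benzimidazol-6-yl, and the rest of the molecule stays as it was.

For the measured compounds named here, no measured pair shows this exchange on its own, since compound 1 and compound 3 each differ from compound 2 in more than one place. Any forecast therefore rests on thin evidence and needs a wide range. Because compound 2 already stands at 4.6%, there is little room for a fall, and a small rise seems the likelier direction. The expected change is a number 9.4 percentage points higher from compound 2 to compound 4 (within the scatter), a modest step that would not clearly stand out from the scatter. For compound 4, the estimated value is 14%, with an expected range from 3% to 40%.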

Compound 4, percent of the compound remaining: 16%
Beside the measured number, compound 4's estimate is 2 percentage points below it, and the stated range covers the measured number.
By their numbers in this assay, from the lowest: compound 2; then compounds 4 and 1 (each within the scatter of the next); then compound 3.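

In this assay, among the compounds shown here, exchanging only the group on the carbonyl carbon for 1H-benzimidazol-6-yl gives a number 11.4 percentage points higher from compound 2 to compound 4 (beyond the scatter), the first step here in which a single place changes while the rest of the molecule stays the same. The step is modest, but it shows that this position alone can shift the number by more than the scatter, even with the group size unchanged at 9 heavy atoms. Nothing shown gives a measured reason for the step.

This single exchange alters several things together: the oxygen leaves, a second nitrogen enters, the six-membered aromatic ring becomes carbon only, and the group goes from 0 hydrogen-bond donors to 1 hydrogen-bond donor, so the pair cannot say which of these matters. Going by these compounds, whether a 1H-indol-6-yl group, which keeps the hydrogen-bond donor with only one nitrogen, or a plain phenyl group on the same carbonyl carbon would behave like the group in compound 2 or the group in compound 4 stays open, as does whether this exchange gives a similar step on another core.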